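Ring in place of chain at the ester of compound 2

A few compounds are considered here, and "the series" means these few. Any claim that something is new, unique, unknown or untested is made for them only; others in the source may bear on it.

Measured so far in an assay on isolated protein for inhibition of Rho-associated protein kinase 2 (Homo sapiens), read by radiometric assay; on this read-out lower numbers stand for stronger inhibition and higher numbers for weaker inhibition:
compound 1 `COC(=O)c1cccc(-c2cc(C(=O)Nc3ccncc3)ccc2CN)c1`: 2.9 nM
compound 2 `CCCOC(=O)c1cccc(-c2cc(C(=O)Nc3ccncc3F)ccc2CN)c1`: 5.1 nM
compound 3 `CCCOC(=O)c1cccc(-c2cc(C(=O)Nc3ccncc3)ccc2CN)c1`: 1.4 nM

Compound 2 has the highest of the three numbers. Compound 1 lies nearest, within the scatter, and the step to the furthest compound is a 3.6-fold lower number from compound 2 to compound 3 (0.56 log units; beyond the scatter), which concerns the fluoro group and not the ester chain.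

Compound 4 `NCc1ccc(C(=O)Nc2ccncc2F)cc1-c1cccc(C(=O)OCC2CC2)c1` carries cyclopropyl in place of ethyl on a saturated chain carbon bound to an oxygen next to a carbonyl group. Among the measured compounds shown here, the one measured step at that place is a 2.1-fold lower number from compound 1 to compound 3 (0.32 log units; beyond the scatter), a modest gain when the chain grows. The fluoro step does not bear on it. Growing the chain further, now into a ring, is expected to move the number little. Compound 4 is therefore estimated at 4 nM, between 1.5 nM and 12 nM. The expected step is a 1.3-fold lower number from compound 2 to compound 4 (0.11 log units; within the scatter), within the scatter.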

Compound 4, half-maximal inhibitory concentration: 2.7 nM
Compound 4: the middle estimate sits 1.5-fold (0.17 log units) above what was measured; the range from low to high includes it.
By their numbers in this assay, from the lowest: compounds 3, 4, 1 and 2 (each within the scatter of the next, the first and the last beyond it).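

In this assay the change gives a 1.9-fold lower number from compound 2 to compound 4 (0.28 log units; within the scatter) and so leaves the number within the scatter of compound 2. The earlier compounds shown here showed only open chains at this place, whereas compound 4 shows that a three-membered ring of carbon is tolerated on a saturated chain carbon bound to an oxygen next to a carbonyl group, with the fluoro group present. No supporting evidence is available to explain this result.

As far as these compounds go, whether cyclopropylmethoxycarbonyl gives a similar number without the fluoro group remains open. So does how a carboxylic acid or a butyl chain would fare at this place.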